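The source may report more compounds than this note shows. Statements on the series, on what has been measured and on what is new or still open speak of the compounds shown alone.

Measured in a functional assay on MCF7 cells (Homo sapiens) for inhibition, read by sulforhodamine B assay; a higher number here means a weaker inhibitor, a lower number a stronger inhibitor:
compound 1, `O=C1C=C(N2CCC2)C(=O)c2c1nc1n2[C@H]2OC[C@@H](O)[C@H]2OC1`: > 16000 nM
compound 2, `O=C1C=C(Nc2ccccc2F)C(=O)c2c1nc1n2[C@H]2OC[C@@H](O)[C@H]2OC1`: 3640 nM
compound 3, `Cc1ccc(NC2=CC(=O)c3c(nc4n3[C@H]3OC[C@@H](O)[C@H]3OC4)C2=O)cc1`: > 4000 nM

The value of compound 1 is a limit of this assay, (the limit of > 16000 nM in this assay, at which 1 of the 3 values shown sits). The value of compound 3 is likewise a limit, (the limit of > 4000 nM in this assay, at which 1 of the 3 values shown sits). Compound 2 alone gives a number. Among the measured compounds shown here, the one measured step, an at least 4.3-fold lower number from compound 1 to compound 2 (0.64 log units; beyond the scatter), exchanges azetidin-1-yl for (2-fluorophenyl)amino and says nothing about changes within an aryl group.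

Compound 4, `COc1cccc(NC2=CC(=O)c3c(nc4n3[C@H]3OC[C@@H](O)[C@H]3OC4)C2=O)c1`, differs from compound 3 by 3-methoxyphenyl in place of 4-methylphenyl on an amine nitrogen. For the measured compounds named here, no measured step bears on this change, so no direction is expected beyond the scatter; compound 4 is expected to stay near compound 3, with a step that the limit leaves unreadable from compound 3 to compound 4. Compound 4 is estimated at 6000 nM, between 2500 nM and 16000 nM, with a fair chance that only a limit is reported.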

Compound 4, half-maximal inhibitory concentration: 3830 nM
For compound 4 the middle estimate is 1.6-fold (0.19 log units) above the measured one; measured number inside the range.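

In this assay compound 4 gives a number, 3830 nM, so 3-methoxyphenyl on this amine nitrogen yields a readable value. Compound 3 gives only a limit: the limit of > 4000 nM in this assay, at which 1 of the 4 values shown sits. The step is an at least 1.0-fold lower number from compound 3 to compound 4 (0.01 log units; that floor lies within the scatter), so no direction can be assigned to the change from 4-methylphenyl to 3-methoxyphenyl.

Still open, going by these compounds, is how the series responds to a benzyl group or a pyridyl ring on the same amine nitrogen. Also open, on these data alone, is the effect of a carboxylic acid on the phenyl ring.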